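Methylating the aromatic hydroxy of compound 1

This account rests on a few compounds, and the source may have more. Where it says the series, first, only, none or still open, it means among the compounds named here.

Going by the values given here, in a functional assay on SNO cells (Homo sapiens) for cytotoxicity, read by XTT assay, with a stated time of 24 h (on this read-out lower numbers stand for stronger inhibition and higher numbers for weaker inhibition), compound 1 `Cc1cc(Cl)c2c(c1O)C(=O)C=CC2=O` gives 9400 nM as the lower of the two numbers so far, and compound 2 `CC(=O)Oc1cc(OC(C)=O)c2c(OC(C)=O)cc(C)c(Cl)c2c1OC(C)=O` gives 56900 nM with a gap beyond the scatter. Compound 3 `COc1c(C)cc(Cl)c2c1C(=O)C=CC2=O` is not yet measured. Its difference from compound 1 is methyl in place of hydrogen on an oxygen on an aromatic ring with methyl in place of hydrogen on an oxygen on an aromatic ring. Among the compounds with values here, no measured pair shows this change, so the expectation is loose. A modest weakening in this assay is expected, with the estimated step of a 1.6-fold higher number from compound 1 to compound 3 (0.20 log units; within the scatter) as the working figure. For compound 3 the expected value is 15000 nM within an estimated range of 5000 nM to 45000 nM on this read-out.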

Compound 3, half-maximal inhibitory concentration: 44900 nM
Beside the measured number, compound 3's estimate is 3.0-fold (0.48 log units) below it; the measured number falls inside the stated range.
By their numbers in this assay, from the lowest: compound 1; then compounds 3 and 2 (each within the scatter of the next).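

Hydroxy to methoxy gives the first single-place step in the series: in this assay, the change is a 4.8-fold higher number from compound 1 to compound 3 (0.68 log units; beyond the scatter). At this oxygen on an aromatic ring, replacing the hydrogen with methyl therefore weakens the read-out beyond the scatter, although this rests on one pair. Nothing available explains the step.

As far as these compounds go, whether an ethyl group on this oxygen, or an amine in place of the hydroxy, would give a smaller or larger step remains open. So does whether the step holds on the other compounds in the series.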